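This account rests on a few compounds, and the source may have more. Where it says the series, first, only, none or still open, it means among the compounds named here.

Measured so far:
compound 1 `NC(=S)N/N=C/c1ccc2ccccc2n1`: > 100000 nM
compound 2 `S=C(N/N=C/c1ccc2ccccc2n1)Nc1ccc(Cl)cc1`: > 100000 nM

In a functional assay on HL-60 cells (Homo sapiens) for antiproliferative activity, read by sulforhodamine B assay, with a stated time of 72 h (a lower number here means a stronger inhibitor, a higher number a weaker inhibitor), compound 1 gives only a limit, > 100000 nM. In this assay compound 2 likewise gives only a limit, > 100000 nM. The step that the two limits leave unreadable from compound 1 to compound 2 is unreadable because both values sit at the same limit (the limit of > 100000 nM in this assay, at which 2 of the 2 values shown sit). Compound 3 `S=C(N/N=C/c1ccc2ccccc2n1)Nc1ccc(Br)cc1` differs from compound 2 by bromo in place of chloro on an aromatic carbon. Going by the values given here, no measured step bears on this change, and compound 2 stands at the limit, so the expected step that the limit leaves unreadable from compound 2 to compound 3 is none beyond the scatter. Compound 3 is thus estimated at 150000 nM, within 50000 nM to 500000 nM, most likely again a limit.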

Compound 3, half-maximal inhibitory concentration: 27500 nM
Estimate against measurement, compound 3: 5.5-fold (0.74 log units) above; measured number outside the range, below it.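

In this assay, the substituent on the 4-phenyl group is not silent: bromo in place of chloro gives an at least 3.6-fold lower number from compound 2 to compound 3 (0.56 log units; beyond the scatter). Set against the unsubstituted nitrogen of the core, 4-bromophenyl gives an at least 3.6-fold lower number from compound 1 to compound 3 (0.56 log units; beyond the scatter), so a substituent on that nitrogen can carry measurable activity when it ends in bromo. The step from compound 1 to compound 2 cannot be read, and compound 3 alone gives a number rather than a limit: the limit of > 100000 nM in this assay, at which 2 of the 3 values shown sit.

On these data alone, whether iodo or an amine at the same place would extend this change remains open. As far as these compounds go, a longer chain on that nitrogen also remains untested against 4-bromophenyl.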